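This account rests on a few compounds, and the source may have more. Where it says the series, first, only, none or still open, it means among the compounds named here.

In a functional assay on RAW264.7 cells (Mus musculus) for inhibition, read by Griess assay, with a stated time of 20 h (a higher number here means a weaker inhibitor, a lower number a stronger inhibitor), three compounds that share one core have been tested so far. Compound 1 `CCCNC(=O)c1cc(-n2cc(-c3ccccc3)nn2)ccc1O` gives > 20000 nM, which is a limit of the assay and not a number. Compound 2 `CCCNC(=O)c1cc(-n2cc(CCC(C)C)nn2)ccc1O` gives > 20000 nM, again a limit. Compound 3 `CCCNC(=O)c1cc(-n2cc(-c3cccc(Cl)c3)nn2)ccc1O` gives > 20000 nM, also a limit, so it has no number of its own. The whole set rests on (the limit of > 20000 nM in this assay, at which 3 of the 3 values shown sit).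

Compound 4 `CCCNC(=O)c1cc(-n2cc(-c3cc(F)cc(F)c3)nn2)ccc1O` carries 3,5-difluorophenyl in place of 3-chlorophenyl, on an aromatic carbon of a five-membered aromatic ring with 3 nitrogen, and the change counts as 3,5-difluorophenyl in place of 3-chlorophenyl on an aromatic carbon. For the measured compounds named here, three measured steps bear on this: a step that the two limits leave unreadable from compound 1 to compound 3, a step that the two limits leave unreadable from compound 2 to compound 3 and a step that the two limits leave unreadable from compound 1 to compound 2. None has a readable size, so they point in no direction, and no step beyond the scatter is expected. The expected step is a number no higher from compound 3 to compound 4 (the limit leaves the size open). Compound 4 is estimated at 20000 nM, with an expected range from 8000 nM to 40000 nM.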

Compound 4, half-maximal inhibitory concentration: > 20000 nM
Compound 4: a limit, no number; the forecaster's own chance of this, stated with the estimate: 75%; the middle value lies on the limit itself.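

Compound 4 gives > 20000 nM in this assay, which is a limit of the assay and not a number, so its steps from compound 1, compound 2 and compound 3 cannot be read. The compounds shown leave open whether any group at this place changes the inhibition at all, and they offer only this: the limit of > 20000 nM in this assay, at which 4 of the 4 values shown sit.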